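The compounds below may be only part of what the source reports. "The series", "measured", "known", "first", "only" and "open" are said of these compounds alone.

Three compounds share one core and differ only in the group attached to the carbonyl carbon of a short side chain. Compound 1 `COc1cc2c(cc1OC)C(CC(=O)O)CC2` carries an acid there, and in a functional assay on the whole organism (strain Wistar) for inhibition, with Rattus norvegicus as the target, read by paw edema, with stated times of 60 min and 1 h, at a dose of 100 mg/kg by the oral route (a lower number here means less inhibition, a higher number more inhibition at the dose given (going by the name of the read-out)), compound 1 gives 18.8%. Compound 2 `CCCNC(=O)CC1CCc2cc(OC)c(OC)cc21` carries a propylamino group instead, and in this assay compound 2 gives 18.8%, so that no change at the digits printed from compound 1 to compound 2 (within the scatter). Compound 3 `COc1cc2c(cc1OC)C(CC(=O)NC1CCCCC1)CC2` carries a cyclohexylamino group; in this assay compound 3 gives 50%, a step of a number 31.2 percentage points higher from compound 1 to compound 3 (beyond the scatter) from the acid and of a number 31.2 percentage points higher from compound 2 to compound 3 (beyond the scatter) from the propyl amide. Compound 2 thus stands level with compound 1, the two together forming the lowest pair of the three numbers, with compound 3 well above both.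

Compound 4 `COc1cc2c(cc1OC)C(CC(=O)NCCO)CC2` takes one step from compound 2: hydroxy in place of methyl on a saturated chain carbon, two bonds along the chain from an amide-type nitrogen. Within the data shown here, the only measured step touching the amide side is the one on the nitrogen, a number 31.2 percentage points higher from compound 2 to compound 3 (beyond the scatter), which exchanged a chain for a ring. Among the measured compounds shown here, no measured pair shows a hydroxy entering a chain end, so there is no direct guide. Since the acid of compound 1 and the propyl amide of compound 2 sit level, a small change far out on the chain is expected to stay within the scatter. Compound 4 is therefore estimated to give 20%, with a range from 5% to 40%, which means an expected step of a number 1.2 percentage points higher from compound 2 to compound 4 (within the scatter).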

Compound 4, a percentage reported as inhibition, in the whole organism at one dose (the size of the read-out at that dose, not a potency): 0%
The estimate for compound 4 lay 20 percentage points above the measured number; the whole stated range lies above it.
By their numbers in this assay, from the lowest: compound 4; then compounds 1 and 2 (each within the scatter of the next); then compound 3.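

The change from methyl to hydroxy, on a saturated chain carbon, two bonds along the chain from an amide-type nitrogen, replaces just one heavy atom, yet in this assay it gives a number 18.8 percentage points lower from compound 2 to compound 4 (beyond the scatter). This shows that the amide chain is sensitive at this position, which the earlier swap of hydroxy for propylamino on the carbonyl carbon did not suggest, since that step gave no change at the digits printed from compound 1 to compound 2 (within the scatter). The (2-hydroxyethyl)amino group also gives a number 18.8 percentage points lower from compound 1 to compound 4 (beyond the scatter), so an amide here can fall below the acid, and 2-hydroxyethyl in place of cyclohexyl gives a number 50 percentage points lower from compound 3 to compound 4 (beyond the scatter), which places the group on the nitrogen behind the whole spread seen so far, from compound 4 at 0% to compound 3 at 50%.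

No measurement here explains why the read-out drops. The compounds shown leave open whether this drop belongs to hydroxy alone or to the length of the chain carrying it, a question that a 2-aminoethyl, 2-methoxyethyl or 3-hydroxypropyl group on the nitrogen could help to answer.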